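Sulfamoyl Urea to Carbamate: Expected Change in Liver Enzyme Inhibition

The compounds below may be only part of what the source reports. "The series", "measured", "known", "first", "only" and "open" are said of these compounds alone.

Compound 1 `CCC(C)N(C(=O)NS(=O)(=O)Oc1c(C(C)C)cccc1C(C)C)C(C)CC` is a sulfamoyl urea carrying a bis(sec-butyl)amino group. In an assay on liver for inhibition of sterol O-acyltransferase 1 (Rattus norvegicus), using microsomes (a higher number here means a weaker inhibitor, a lower number a stronger inhibitor), compound 1 gives 12000 nM. Among the numbers shown it sits lowest: the nearest is compound 2 `CC(C)c1cccc(C(C)C)c1OC(=O)NS(=O)(=O)Nc1ccccc1`, which in this assay gives 38100 nM, a gap beyond the usual scatter. Compound 3 `CC(C)c1cccc(C(C)C)c1OC(=O)NS(=O)(=O)Oc1c(C(C)C)cc(O)cc1C(C)C` reaches only the limit of this assay, > 50000 nM, so no number is known for it.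

Compound 4 `CC(C)c1cccc(C(C)C)c1OS(=O)(=O)NC(=O)Oc1ccc(F)cc1` has not yet been measured in this assay. It differs from compound 1 in one place: 4-fluorophenoxy in place of bis(sec-butyl)amino on a carbonyl carbon. No directly comparable step between measured compounds is shown, so the size of the change can only be estimated. Compound 3, a carbamate-type compound, sits at the limit of this assay. Since the other carbamate-type compound shown, compound 2 with 38100 nM, sits weaker than compound 1, the step is expected to move upward, that is toward weaker inhibition, by a moderate amount beyond the scatter: a 2.1-fold higher number from compound 1 to compound 4 (0.32 log units; beyond the scatter) is the expected step. Compound 4 is therefore expected to give about 25000 nM in this assay, most likely between 8000 nM and 60000 nM.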

Compound 4, half-maximal inhibitory concentration: > 50000 nM
Compound 4: only a limit was reported; the forecaster's own chance of this, stated with the estimate: 25%; middle value at least 2.0-fold (0.30 log units) from the limit.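

Placing 4-fluorophenoxy on the carbonyl carbon instead of bis(sec-butyl)amino weakens inhibition in this assay, with an at least 4.1-fold higher number from compound 1 to compound 4 (0.61 log units; beyond the scatter). Within the data shown here, this is the first direct reading at this position, as the other measured compounds differ from compound 1 in more than one place, and it shows that the group held here affects inhibition. Compound 4 gives > 50000 nM, a limit of the assay and not a number, so the full size of the loss remains unknown: the limit of > 50000 nM in this assay, at which 2 of the 4 values shown sit.

The swap changes the atom joined to the carbonyl carbon and adds a ring at the same time, and the compounds shown do not tell which of the two matters. A phenylamino group or a sec-butoxy group on this carbonyl carbon would separate these two changes.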